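Moving the Fluorine on a Benzyl Group

The compounds below may be only part of what the source reports. "The series", "measured", "known", "first", "only" and "open" are said of these compounds alone.

Compound 1 `CC1CCN(C2CCN(S(=O)(=O)c3ccc(-c4ccccc4F)cc3)CC2)CC1`: > 5000 nM
Compound 2 `CC(=O)Nc1ccc(S(=O)(=O)N2CCC(N3CCC(C)CC3)CC2)c2ccccc12`: > 10000 nM
Compound 3 `Cc1cc(C)c(S(=O)(=O)N2CCC(N3CCC(Cc4ccc(F)cc4)CC3)CC2)c(C)c1`: > 5000 nM

All three values come from an ADME assay on HCT-116 cells (Homo sapiens) for cytotoxicity, read by CellTiter-Glo, with a stated time of 72 h (a lower number here means a stronger inhibitor, a higher number a weaker inhibitor), and each one is a limit of the assay rather than an exact number. Compound 3 gives > 5000 nM, which is such a limit. The other two compounds offer no exact number to compare it with, so no ranking among the three can be drawn.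

The next compound to be tested is compound 4 `Cc1cc(C)c(S(=O)(=O)N2CCC(N3CCC(Cc4ccccc4F)CC3)CC2)c(C)c1`, which contains the same atoms as compound 3, joined differently. It carries 2-fluorophenyl in place of 4-fluorophenyl on a saturated chain carbon bound to a saturated ring carbon. Read one bond further out, this is 4-fluorobenzyl changing to 2-fluorobenzyl.

Among the compounds with values here, no two measured compounds here differ in only one place, so the set gives no direct measure of what such a change does. With compound 3 at > 5000 nM, a limit, compound 4 is expected to stay weak in this assay, and another limit is the most likely report. The expected shift, a step that the limit leaves unreadable from compound 3 to compound 4, is no larger than the usual scatter and favours neither direction. The estimated value for compound 4 is 7000 nM, with an expected range of 3000 nM to 15000 nM.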

Compound 4, half-maximal inhibitory concentration: > 5000 nM
Compound 4 ended at the assay's limit (the forecaster's own chance of this, stated with the estimate: 85%); the middle value does not contradict the limit.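

Within the data shown here, compound 3 and compound 4 both stop at a limit in this assay, so moving the fluorine from 4-fluorobenzyl to 2-fluorobenzyl gives no step that can be read. The compounds shown leave open what exact value any of them has in this assay, and whether either fluorine placement gives the lower number.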